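The compounds below may be only part of what the source reports. "The series", "measured", "known", "first", "only" and "open" are said of these compounds alone.

Measured so far in a functional assay on Huh-7 cells (Homo sapiens) for inhibition, read by MTT assay, with a stated time of 48 h; a higher number here means a weaker inhibitor, a lower number a stronger inhibitor:

Compound 1, `COc1ccc2c(=O)c(/C=C/C(=O)NCc3ccccc3)coc2c1`: 13600 nM
Compound 2, `COc1ccc2c(=O)c(/C=C/C(=O)Nc3ccccc3Cl)coc2c1`: 58400 nM
Compound 3, `COc1ccc2c(=O)c(/C=C/C(=O)Nc3cc(C)ccc3C)coc2c1`: 11100 nM

Among these three numbers compound 1 stands second highest. Compound 3 sits nearest to it, and the step of a 1.2-fold lower number from compound 1 to compound 3 (0.09 log units; within the scatter) lies within the scatter, so no order between compound 1 and compound 3 can be read from this assay. Compound 2 is furthest away, with a 4.3-fold higher number from compound 1 to compound 2 (0.63 log units; beyond the scatter), a step beyond the scatter; likewise a 5.3-fold lower number from compound 2 to compound 3 (0.72 log units; beyond the scatter) is beyond the scatter.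

The next compound is compound 4, `COc1ccc2c(=O)c(/C=C/C(=O)NCc3ccc(F)cc3)coc2c1`. It differs from compound 1 only in this: fluoro in place of hydrogen on an aromatic carbon. The group enters on an aromatic carbon of the six-membered aromatic ring of carbon only, para to a large group; the change leaves the benzyl attachment to the amide-type nitrogen itself untouched.

Going by the values given here, none of the measured steps bears on this change directly. Each of a 4.3-fold higher number from compound 1 to compound 2 (0.63 log units; beyond the scatter), a 1.2-fold lower number from compound 1 to compound 3 (0.09 log units; within the scatter) and a 5.3-fold lower number from compound 2 to compound 3 (0.72 log units; beyond the scatter) swaps the whole group on the amide-type nitrogen, including the link between that nitrogen and the ring, whereas the change to compound 4 adds a single fluorine to the ring of compound 1 and keeps everything else. The measured steps therefore give no direction for the fluoro substitution, and the expectation rests on the change being small. For compound 4 the step is estimated as a 1.0-fold lower number from compound 1 to compound 4 (0.02 log units; within the scatter), that is, no step beyond the scatter in this assay. Compound 4 is thus expected to give about 13000 nM, within roughly 6000 nM to 30000 nM.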

Compound 4, half-maximal inhibitory concentration: 21000 nM
Estimate against measurement, compound 4: 1.6-fold (0.21 log units) below; low and high end bracket the measured number.
By their numbers in this assay, from the lowest: compounds 3, 1 and 4 (each within the scatter of the next); then compound 2.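

In this assay, a fluoro on the aromatic carbon para to a large group of the benzyl ring of compound 1 leaves the number within the scatter (a 1.5-fold higher number from compound 1 to compound 4 (0.19 log units; within the scatter)), so benzyl and 4-fluorobenzyl cannot be told apart at this position. Going by these compounds alone, the fluorinated benzyl also stays within the scatter of the 2,5-dimethylphenyl group (a 1.9-fold higher number from compound 3 to compound 4 (0.28 log units; within the scatter)), while the gap to the 2-chlorophenyl group remains beyond it (a 2.8-fold lower number from compound 2 to compound 4 (0.44 log units; beyond the scatter)), which leaves compound 2 as the only compound set apart from compounds 1, 3 and 4 by steps beyond the scatter. No measurement at hand accounts for any of these steps.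

Whether the benzyl ring tolerates other groups in this place is open: a chloro, a methoxy, a trifluoromethyl, an amine or a carboxylic acid could each move the number beyond the scatter, in either direction. Also open, going by these compounds, is how a longer chain between the amide-type nitrogen and the ring would compare with the benzyl link of compound 1.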